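This account rests on a few compounds, and the source may have more. Where it says the series, first, only, none or still open, it means among the compounds named here.

Compound 1, `O=[N+]([O-])c1cccc2c1CCN(c1ncnc3c1nc1n3[C@@H]3O[C@H](CO1)[C@@H](O)[C@H]3O)C2`: 7410000 nM
Compound 2, `O=[N+]([O-])c1cccc2c1CN(c1ncnc3c1nc1n3[C@@H]3O[C@H](CO1)[C@@H](O)[C@H]3O)CC2`: 1740000 nM
Compound 3, `OC[C@H]1O[C@@H](n2cnc3c(SCC4CCCCC4)ncnc32)[C@H](O)[C@@H]1O`: 1550 nM

Of the compounds shown here, three have been measured in an assay on isolated protein for binding affinity to Equilibrative nucleoside transporter 1 (Homo sapiens); a lower number here means a stronger inhibitor, a higher number a weaker inhibitor. Compound 3 stands lowest of the three: in this assay compound 3 gives 1550 nM, and its gap to compound 2, the nearest of the other two, lies well beyond the scatter, as does its gap to compound 1. Compound 3 is thus the strongest inhibitor of the set, and compounds 1 and 2 share a different core, so neither offers a step that isolates one change.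

Compound 4, `CCSc1ncnc2c1ncn2[C@@H]1O[C@H](CO)[C@@H](O)[C@H]1O`, has not yet been measured. It differs from compound 3 in one place: methyl in place of cyclohexyl on a saturated chain carbon bound to a sulfur. For the measured compounds named here, no pair of measured compounds shows a step of this kind, so the expectation rests on the value of compound 3 alone. The change removes a ring and shrinks the side chain to a single carbon, and the step from compound 3 to compound 4 is expected to be a 19-fold higher number from compound 3 to compound 4 (1.29 log units; beyond the scatter), toward a weaker inhibitor and beyond the scatter. Compound 4 is therefore estimated at 30000 nM, with a range from 5000 nM to 200000 nM.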

Compound 4, half-maximal inhibitory concentration: 57500 nM
Compound 4: the middle estimate sits 1.9-fold (0.28 log units) below what was measured, within the range that was stated.
By their numbers in this assay, from the lowest: compound 3; then compound 4; then compound 2; then compound 1.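

In this assay, putting methyl in place of cyclohexyl on a saturated chain carbon bound to a sulfur gives a 37-fold higher number from compound 3 to compound 4 (1.57 log units; beyond the scatter), a large step and the first in this set that isolates a single change. It shows that the number at this position depends strongly on the group carried there, with the cyclohexylmethyl of compound 3 giving a much stronger inhibitor than the ethyl of compound 4. Nothing in the available information accounts for the size of this step.

As far as these compounds go, this single step does not separate the loss of the ring from the shortening of the chain, so it remains open whether a longer open chain such as hexyl would keep the value of compound 3. From the compounds shown here alone, it also remains open how a benzyl group or an amine-bearing ring would behave at this position.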